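Carboxyphenyl in place of neopentylphenyl on the cyclopentane urea series

A few compounds are considered here, and "the series" means these few. Any claim that something is new, unique, unknown or untested is made for them only; others in the source may bear on it.

Measured compounds:
compound 1 `Cc1ccc(C2(CNC(=O)Nc3c(C(C)C)cccc3C(C)C)CCCC2)cc1` gives 25 nM
compound 2 `CC(C)c1cccc(C(C)C)c1NC(=O)NCC1(c2ccc(CC(C)(C)C)cc2)CCCC1` gives 159 nM
compound 3 `CC(C)c1cccc(C(C)C)c1NC(=O)NCC1(c2cccc([N+](=O)[O-])c2)CCCC1` gives 51 nM

In an assay on microsomes for inhibition of acyl-CoA:cholesterol acyltransferase (Oryctolagus cuniculus) (on this read-out higher numbers stand for weaker inhibition and lower numbers for stronger inhibition), compound 2 stands highest of the three, with compound 3 nearest at a 3.1-fold lower number from compound 2 to compound 3 (0.49 log units; beyond the scatter) and compound 1 furthest at a 6.4-fold higher number from compound 1 to compound 2 (0.80 log units; beyond the scatter) read in reverse. Compound 4 `CC(C)c1cccc(C(C)C)c1NC(=O)NCC1(c2cccc(C(=O)O)c2)CCCC1` is not yet measured. It differs from compound 2 in one place: 3-carboxyphenyl in place of 4-neopentylphenyl on a saturated ring carbon.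

Going by the values given here, two measured steps bear on this change. Both replace the 4-neopentylphenyl or a group of its size by a smaller aryl group, and both lower the number: a 3.1-fold lower number from compound 2 to compound 3 (0.49 log units; beyond the scatter) and, for the related change at the same place, a 2.0-fold higher number from compound 1 to compound 3 (0.31 log units; beyond the scatter) in reverse. Neither measured compound carries a hydrogen-bond donor on that ring, so the size of the step is uncertain. A modest step toward a lower number, a 1.4-fold lower number from compound 2 to compound 4 (0.16 log units; within the scatter), is expected for compound 4. Compound 4 is therefore estimated at 110 nM, in the range 30 nM to 800 nM.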

Compound 4, half-maximal inhibitory concentration: 620 nM
The estimate for compound 4 lay 5.6-fold (0.75 log units) below the measured number, and the stated range covers the measured number.
By their numbers in this assay, from the lowest: compound 1; then compound 3; then compound 2; then compound 4.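

In this assay, the carboxy group reverses the direction seen with compound 3: replacing 4-neopentylphenyl with 3-carboxyphenyl gives a 3.9-fold higher number from compound 2 to compound 4 (0.59 log units; beyond the scatter), so a smaller group on the saturated ring carbon does not by itself lower the number. The group carried by the aromatic ring matters strongly, as carboxy in place of nitro gives a 12-fold higher number from compound 3 to compound 4 (1.08 log units; beyond the scatter), and the widest gap in the set is a 25-fold higher number from compound 1 to compound 4 (1.39 log units; beyond the scatter). Nothing available here accounts for this rise.

The compounds shown leave open whether a methyl ester or a primary amide in place of the carboxy group would stay close to compound 3 or to compound 4. They also do not show how a hydroxyl or an amine would behave on the same aromatic ring.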